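Lengthening the chain on compound 2

The compounds below may be only part of what the source reports. "The series", "measured", "known", "first", "only" and "open" are said of these compounds alone.

Values in a functional assay on HCT-116 cells (Homo sapiens) for inhibition, read by MTT assay, with a stated time of 72 h; a lower number here means a stronger inhibitor, a higher number a weaker inhibitor:
compound 1 `CNC(=O)CCCCCCCn1nc(-c2cnc3[nH]ccc3c2)c2c(N)ncnc21` 6760 nM
compound 2 `Nc1ncnc2c1c(-c1cnc3[nH]ccc3c1)nn2CC(=O)NO` > 150000 nM (a limit)
compound 3 `Nc1nc2cc(-c3nn(CCCC(=O)NO)c4ncnc(N)c34)ccc2o1` 19600 nM

Compound 2 has no number, only a limit, and stands at the limit of > 150000 nM in this assay, at which 1 of the 3 values shown sits. The change to compound 4 `Nc1ncnc2c1c(-c1cnc3[nH]ccc3c1)nn2CCCCCC(=O)NO` puts 4-(hydroxycarbamoyl)butyl in place of hydroxycarbamoyl on a saturated chain carbon bound to an aromatic nitrogen. For the measured compounds named here, the one measured step at this place is an at least 22-fold higher number from compound 1 to compound 2 (1.34 log units; beyond the scatter), which is large and beyond the scatter. It ends in the short group of compound 2, whereas the step to compound 4 goes back to a longer one, though with a different end group from compound 1. Compound 3 also carries hydroxycarbamoyl on a chain, differs in its core as well, and gives 19600 nM. On the step from compound 1, a large move to a lower number is expected in this assay, and the estimated step is an at least 37-fold lower number from compound 2 to compound 4 (1.57 log units; beyond the scatter). For compound 4 the estimated value is 4000 nM, with an expected range of 500 nM to 25000 nM.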

Compound 4, half-maximal inhibitory concentration: 63700 nM
Compound 4: the middle estimate sits 16-fold (1.20 log units) below what was measured; measured number above the stated range.
By their numbers in this assay, from the lowest: compound 1; then compound 3; then compound 4. At a limit, above all of these: compound 2.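

In this assay, putting 4-(hydroxycarbamoyl)butyl in place of hydroxycarbamoyl on the saturated chain carbon bound to an aromatic nitrogen gives an at least 2.3-fold lower number from compound 2 to compound 4 (0.37 log units; beyond the scatter), so the longer chain ending in hydroxycarbamoyl reaches a measurable value on the shared core. Compound 2 has only a limit, so the true size of this step stays unknown: the limit of > 150000 nM in this assay, at which 1 of the 4 values shown sits.

Chain extension alone does not match compound 1: hydroxycarbamoyl in place of 2-(methylcarbamoyl)ethyl gives a 9.4-fold higher number from compound 1 to compound 4 (0.97 log units; beyond the scatter), so at this position the methylcarbamoyl-ended chain of compound 1 has the lower number.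

Still open, as far as these compounds go, is whether a longer chain ending in hydroxycarbamoyl lowers the number further, and how a carboxylic acid or a primary amine at the chain end would compare. Compound 3 gives no direct reading here, as its core differs as well.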